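Working notes: amino in place of methyl, compound 4

The compounds below may be only part of what the source reports. "The series", "measured", "known", "first", "only" and "open" are said of these compounds alone.

The three measured compounds share one core and differ at a single aromatic carbon. Compound 1 `Cc1ncc(-c2ccccc2)c(C(C)(C)C)n1` carries a methyl there, and in a functional assay on the whole organism for inhibition, with Rattus norvegicus as the target, with stated times of 1 h and 3.5 h, at a dose of 100 mg/kg by the oral route (on this read-out lower numbers stand for less inhibition and higher numbers for more inhibition at the one dose given (going by the name of the read-out)), compound 1 gives 22%. Compound 2 `CC(C)(C)c1nc(NC(N)=O)ncc1-c1ccccc1` carries a ureido group, and in this assay compound 2 gives 14%. Compound 3 `CNc1ncc(-c2ccccc2)c(C(C)(C)C)n1` carries a methylamino group, and in this assay compound 3 gives 37%, the highest number of the three: a number 15 percentage points higher from compound 1 to compound 3 (beyond the scatter), and a number 23 percentage points higher from compound 2 to compound 3 (beyond the scatter), whereas a number 8 percentage points lower from compound 1 to compound 2 (within the scatter).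

Within the data shown here, compound 4 `CC(C)(C)c1nc(NN)ncc1-c1ccccc1` is not yet measured. amino in place of methyl on a nitrogen on an aromatic ring The only step on record that touches this nitrogen is a number 23 percentage points higher from compound 2 to compound 3 (beyond the scatter), a modest rise when the carbamoyl group was taken off in favour of methyl. Among the measured compounds shown here, no measured pair shows the effect of an amino group on this nitrogen, so the expectation rests on that single step alone: substitution on this nitrogen other than methyl has so far gone with the lower number, and a modest downward step in this assay is therefore expected, though it may well stay within the scatter.

In this assay compound 4 is expected to give 27%, with a range from 10% to 45%. The expected step is a number 10 percentage points lower from compound 3 to compound 4 (within the scatter).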

Compound 4, a percentage reported as inhibition, in the whole organism at one dose (the size of the read-out at that dose, not a potency): < 5%
Compound 4: a limit, no number (the forecaster's own chance of this, stated with the estimate: 0%); middle value at least 22 percentage points from the limit.
By their numbers in this assay, from the lowest: compounds 2 and 1 (each within the scatter of the next); then compound 3. At a limit, below all of these: compound 4.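

In this assay compound 4 stands at a limit of the assay, not at a number: the limit of < 5% in this assay, at which 1 of the 4 values shown sits. Amino in place of methyl on this nitrogen brings a large fall (a number at least 32 percentage points lower from compound 3 to compound 4 (beyond the scatter)), so exchanging one heavy atom, in the change from methylamino to aminoamino, is enough to move the read-out well beyond the scatter, and methyl now holds the higher number against both carbamoyl and amino on this nitrogen. Against the methyl of compound 1 on the aromatic carbon, the fall also clears the scatter (a number at least 17 percentage points lower from compound 1 to compound 4 (beyond the scatter)), whereas against the carbamoyl group of compound 2 the floor of the step stays within it (a number at least 9 percentage points lower from compound 2 to compound 4 (that floor lies within the scatter)), which leaves compound 2 and compound 4 not firmly separated.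

The compounds shown leave open how far the higher number extends beyond methyl on this nitrogen, for which ethyl, dimethylamino or a hydroxyl group in place of amino would be the direct comparisons. They also leave open whether the fall with amino persists when the phenyl or tert-butyl group of the shared core is replaced, for example by a chlorophenyl or an isopropyl group.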